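This account rests on a few compounds, and the source may have more. Where it says the series, first, only, none or still open, it means among the compounds named here.

Measured so far in a physicochemical assay for pharmacokinetics, read by LC-MS, in phosphate buffer, at pH 7.4, in the presence of a further agent that is not named here; a higher number here means that the compound lasts longer, a lower number that the compound disappears faster:

- compound 1, `C=CC(=O)N1CC(NC(=O)Cn2cc(C(=O)N3CCc4cc(Cl)ccc4C3)c3cc(Br)ccc32)C1`, gives 1.67 h
- compound 2, `C=CC(=O)N1CC(NC(=O)Cn2c(C3CC3)c(C(=O)N3CCc4c(cccc4OC)C3)c3cc(Br)ccc32)C1`, gives 1.67 h

Compound 2 stands level with compound 1 in this assay at the digits read; the two values lie within the scatter of each other, and with no single-point change between them nothing more can be drawn from the pair. Compound 3, `C=CC(=O)N1CC(NC(=O)Cn2cc(C(=O)N3CCc4c(cccc4OC)C3)c3cc(Br)ccc32)C1`, is the next member; it differs from compound 2 by hydrogen in place of cyclopropyl on an aromatic carbon. Among the measured compounds shown here, nothing measured so far shows what this change does in this assay. The two half-lives in hand agree with each other, so no step beyond the scatter is expected in either direction. Compound 3 is thus estimated at 1.6 h, with a range of 0.8 h to 3.2 h, which means an expected step of a 1.0-fold lower number from compound 2 to compound 3 (0.02 log units; within the scatter).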

Compound 3, half-life: 1.67 h
Compound 3: the middle estimate sits 1.0-fold (0.02 log units) below what was measured; measured number inside the range.
By their numbers in this assay, from the lowest: compounds 1, 2 and 3 (each within the scatter of the next).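

Hydrogen in place of cyclopropyl on an aromatic carbon, next to the ring nitrogen, gives no change at the digits printed from compound 2 to compound 3 (within the scatter) in this assay, so with the rest of compound 2 held fixed, the half-life does not register the loss of this three-membered ring. Exchange of the group on the carbonyl carbon gives no change at the digits printed from compound 1 to compound 3 (within the scatter) in this assay, so a second single-place change also stays within the scatter, and both sites now have a direct reading. No measured data bear on why these half-lives agree.

Both readings rest on one pair each, so they do not show whether another group on this aromatic carbon, such as an amine or a carboxylic acid, would shift the half-life. Going by these compounds, what sets the half-life shared by these compounds remains open, since the acrylamide and the rest of the shared core are the same in all of them.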